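This account rests on a few compounds, and the source may have more. Where it says the series, first, only, none or still open, it means among the compounds named here.

Compound 3 `O=c1ccoc2cc(OCc3cn(Cc4ccc(Cl)cc4Cl)nn3)ccc12` is the only one of the three measured compounds to give a number in a functional assay on HeLa cells (Homo sapiens) for cytotoxicity, read by MTT assay, with a stated time of 48 h (on this read-out higher numbers stand for weaker inhibition and lower numbers for stronger inhibition), where compound 3 gives 80600 nM. Compound 1 `Cc1cccc(Cn2cc(COc3ccc4c(=O)ccoc4c3)nn2)c1` reaches only the limit of this assay, giving > 100000 nM. Compound 2 `O=c1ccoc2cc(OCc3cn(Cc4cccc(Br)c4)nn3)ccc12` likewise sits at the limit, giving > 100000 nM. Compound 4 `O=c1ccoc2cc(OCc3cn(Cc4cccc(Cl)c4)nn3)ccc12` differs from compound 3 by 3-chlorophenyl in place of 2,4-dichlorophenyl on a saturated chain carbon bound to an aromatic nitrogen. Going by the values given here, the steps that bear on this change are an at least 1.2-fold lower number from compound 1 to compound 3 (0.09 log units; that floor lies within the scatter) and an at least 1.2-fold lower number from compound 2 to compound 3 (0.09 log units; that floor lies within the scatter); both rest on (the limit of > 100000 nM in this assay, at which 2 of the 3 values shown sit), so only their floors are readable and those lie within the scatter. Compound 4 is closer in its benzyl group to compound 1 and compound 2 than to compound 3, so a drift back toward the limit is expected, with the estimated step being a 1.4-fold higher number from compound 3 to compound 4 (0.14 log units; within the scatter). Compound 4 is therefore estimated at 110000 nM, within a range of 50000 nM to 250000 nM.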

Compound 4, half-maximal inhibitory concentration: > 100000 nM
Compound 4: no number, only a limit (the forecaster's own chance of this, stated with the estimate: 60%); the middle value does not contradict the limit.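

In this assay, replacing 2,4-dichlorophenyl with 3-chlorophenyl on a saturated chain carbon bound to an aromatic nitrogen gives an at least 1.2-fold higher number from compound 3 to compound 4 (0.09 log units; that floor lies within the scatter), so this change shows no readable loss. Going by these compounds alone, compound 3 remains the only compound with a number, and chloro now joins methyl and bromo among the groups on the phenyl ring that yield only a limit. The steps among compound 1, compound 2 and compound 4 cannot be read: the limit of > 100000 nM in this assay, at which 3 of the 4 values shown sit.

The compounds shown leave open whether an amine or a carboxylic acid in place of the chloro group would give a number in this assay. They also leave open what a longer chain in place of the saturated chain carbon would give.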